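A few compounds are considered here, and "the series" means these few. Any claim that something is new, unique, unknown or untested is made for them only; others in the source may bear on it.

Of the compounds shown here, three sharing one core have been measured in a functional assay on HOP-62 cells (Homo sapiens) for inhibition, read by sulforhodamine B assay; a lower number here means a stronger inhibitor of growth, a higher number a weaker inhibitor of growth. Compound 1 `Oc1cccc2[nH]c(-c3ccc(-c4ccc(-c5ccccc5)cc4)cc3)nc12`, which carries only hydrogen at the far end, gives 9040 nM. Compound 2 `Oc1cccc2[nH]c(-c3ccc(-c4ccc(-c5ccc(F)cc5)cc4)cc3)nc12` gives 8310 nM, and compound 3 `Oc1cccc2[nH]c(-c3ccc(-c4ccc(-c5ccc(C(F)(F)F)cc5)cc4)cc3)nc12` gives 3200 nM, the lowest of the three numbers and the strongest growth inhibition in the set.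

Compound 4 `Oc1ccc(-c2ccc(-c3ccc(-c4nc5c(O)cccc5[nH]4)cc3)cc2)cc1` departs from compound 3 with hydroxy in place of trifluoromethyl on an aromatic carbon, para to a large group, turning 4-(trifluoromethyl)phenyl into 4-hydroxyphenyl: hydroxy in place of trifluoromethyl on an aromatic carbon.

For the measured compounds named here, no measured step places hydroxy here, so the evidence is indirect. Fluoro in place of hydrogen gave a 1.1-fold lower number from compound 1 to compound 2 (0.04 log units; within the scatter), which lies within the scatter. Trifluoromethyl in place of hydrogen gave a 2.8-fold lower number from compound 1 to compound 3 (0.45 log units; beyond the scatter), and trifluoromethyl in place of fluoro gave a 2.6-fold lower number from compound 2 to compound 3 (0.41 log units; beyond the scatter), both modest but beyond the scatter. Compound 3 therefore holds the only measured gain in the set, and removing its trifluoromethyl is expected to give back some or all of that gain, though the data cannot show how hydroxy itself behaves. A modest rise of similar or smaller size is expected, with a 1.9-fold higher number from compound 3 to compound 4 (0.27 log units; within the scatter) as the estimated step. Compound 4 is estimated at 6000 nM, within an expected range of 2500 nM to 14000 nM.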

Compound 4, concentration for 50% growth inhibition: 2410 nM
The estimate for compound 4 lay 2.5-fold (0.40 log units) above the measured number; the measured number lies below the stated range.
By their numbers in this assay, from the lowest: compounds 4 and 3 (each within the scatter of the next); then compounds 2 and 1 (each within the scatter of the next).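

In this assay, hydroxy on this aromatic carbon, para to a large group, gives a 1.3-fold lower number from compound 3 to compound 4 (0.12 log units; within the scatter) in place of trifluoromethyl, so the earlier gain is not unique to trifluoromethyl: a single oxygen with one hydrogen-bond donor and one acceptor reads the same, within the scatter, as a four-atom group with neither. The steps from the other two end groups confirm the separation, with hydroxy in place of fluoro giving a 3.4-fold lower number from compound 2 to compound 4 (0.54 log units; beyond the scatter) and hydroxy in place of hydrogen giving a 3.8-fold lower number from compound 1 to compound 4 (0.57 log units; beyond the scatter) as modest steps beyond the scatter, which places compounds 3 and 4 together and apart from compounds 1 and 2. Nothing measured here explains why two such different groups read alike.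

The compounds shown leave open whether an amine, a carboxylic acid or a methoxy group in this place would read with compounds 3 and 4 or with compounds 1 and 2. They also leave open whether the same grouping would hold if the hydroxy on the shared core were replaced by another group.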